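Replacing the Urea Nitrogen with a Carbon Chain

The source may hold more compounds than are shown below. What is called first, only, known or untested is meant among the compounds shown, and "the series" means these compounds.

Compound 1, `O=C(NCCCCl)Nc1ccc(I)cc1`, gives 90000 nM in a functional assay on HT-29 cells (Homo sapiens) for antiproliferative activity, with a stated time of 48 h; a higher number here means a weaker inhibitor, a lower number a stronger inhibitor. Compound 2, `CC(C)(C)c1ccc(NC(=O)NCCCCl)cc1`, gives 28000 nM in this assay. Compound 3, `CCCCC(O)c1cccc(NC(=O)CCCl)c1`, reaches only the limit of > 100000 nM in this assay.

Among the two numbers, compound 1 holds the higher one; its nearest neighbour is compound 2, reached by a 3.2-fold lower number from compound 1 to compound 2 (0.51 log units; beyond the scatter), a change that touches the aromatic substituent rather than the carbonyl.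

The step to compound 4, `O=C(CCCCl)Nc1ccc(I)cc1`, is of a different kind: 3-chloropropyl in place of (3-chloropropyl)amino on a carbonyl carbon. The urea of compound 1 becomes a plain amide, and the amide hydrogen that the (3-chloropropyl)amino group carried is gone. For the measured compounds named here, no measured step repeats this exact change. Going by the values given here, the one measured step, from compound 1 to compound 2, concerns the aryl group and says little about the carbonyl side. Compound 3, which already carries a 3-chloropropyl on its carbonyl, sits at the limit of > 100000 nM in this assay, at which 1 of the 3 values shown sits, a limit and not a number.

On this basis compound 4 is expected to be no stronger than compound 1, and may well fall beyond the measurable range; the estimate is 130000 nM, within 45000 nM to 350000 nM, so that the expected step is a 1.4-fold higher number from compound 1 to compound 4 (0.16 log units; within the scatter).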

Compound 4, half-maximal inhibitory concentration: > 100000 nM
Compound 4 ended at the assay's limit (the forecaster's own chance of this, stated with the estimate: 55%); the middle value does not contradict the limit.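

For the compounds shown here, compound 4 is the first compound here in which the carbonyl side itself changes, and the swap of (3-chloropropyl)amino for 3-chloropropyl on a carbonyl carbon gives an at least 1.1-fold higher number from compound 1 to compound 4 (0.04 log units; that floor lies within the scatter). In this assay compound 4 gives > 100000 nM, which is a limit of the assay and not a number. The change therefore brings no measurable gain in potency, but the size of any loss stays unknown, since the floor of the step lies within the scatter and the assay cannot place compound 4 any more exactly, like one other compound in the set: the limit of > 100000 nM in this assay, at which 2 of the 4 values shown sit.

On these data alone, it remains open whether the same swap would leave a measurable value on the tert-butyl compound, compound 2, whose number leaves more room beneath the limit than that of compound 1. As far as these compounds go, it is also open whether a carbamate oxygen in place of the urea nitrogen, or a longer chain ending in chlorine, would keep the activity that the urea compounds show.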